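Cytotoxicity of an Alkynyl Uracil Series on Fibroblasts

The compounds below may be only part of what the source reports. "The series", "measured", "known", "first", "only" and "open" are said of these compounds alone.

Compound 2, `O=C1c2ccccc2C(=O)N1C/C=C\Cn1cc(C#CCCc2ccccc2)c(=O)[nH]c1=O`, is the starting point of this step. In an ADME assay on WI-38 cells (Homo sapiens) for cytotoxicity, read by MTT assay, with a stated time of 3 days (on this read-out lower numbers stand for stronger inhibition and higher numbers for weaker inhibition), compound 2 gives > 100000 nM, which is a limit of the assay rather than a number. Compound 1, `Cc1ccc(C#Cc2cn(C/C=C\CN3C(=O)c4ccccc4C3=O)c(=O)[nH]c2=O)cc1`, shares the same core. In this assay compound 1 likewise gives > 100000 nM, again a limit of the assay. The step between them, a step that the two limits leave unreadable from compound 1 to compound 2, cannot be read because of the limit of > 100000 nM in this assay, at which 2 of the 2 values shown sit. Compound 3, `CCCCc1ccc(C#Cc2cn(C/C=C\CN3C(=O)c4ccccc4C3=O)c(=O)[nH]c2=O)cc1`, is not yet measured; it differs from compound 2 in one place: 4-butylphenyl in place of phenethyl on a triple-bonded carbon. Going by the values given here, the only measured step that bears on the same place is the one from compound 1 to compound 2, and its size cannot be read, so no measured step tells how cytotoxicity on this core moves with the group on the triple-bonded carbon. With both known values sitting at the limit, compound 3 is expected to give 150000 nM in this assay, within 50000 nM to 500000 nM. The step this estimate means, a step that the limit leaves unreadable from compound 2 to compound 3, is expected to be nothing beyond the scatter, with the result most likely again reported only as a limit.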

Compound 3, half-maximal inhibitory concentration: 17000 nM
Compound 3: middle estimate off by 8.8-fold (0.95 log units), on the high side, outside the stated range (below it).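

In this assay, going by these compounds alone, the group on the triple-bonded carbon proves able to move the read-out on the shared core, which the earlier compounds could not show: 4-butylphenyl in place of phenethyl gives an at least 5.8-fold lower number from compound 2 to compound 3 (0.76 log units; beyond the scatter). Propyl in place of hydrogen on a saturated chain carbon bound to an aromatic carbon, the change that turns the 4-methylphenyl group of compound 1 into 4-butylphenyl, gives an at least 5.8-fold lower number from compound 1 to compound 3 (0.76 log units; beyond the scatter), so a change of this small kind is enough to bring a measurable number. Compound 3 is the only one of the three with a number rather than a limit, and the step between compound 1 and compound 2 still cannot be read because both sit at that limit: the limit of > 100000 nM in this assay, at which 2 of the 3 values shown sit.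

From the compounds shown here alone, the full size of both new steps stays open, as each is bounded on one side only. Also open, going by these compounds, is whether ethyl or hexyl in place of the butyl chain would shift the number seen for compound 3, and whether an amine or a carboxylic acid on the triple-bonded carbon would keep it.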